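Pyrazine amides on the quinoline core: demethylated analogue

The source may report more compounds than this note shows. Statements on the series, on what has been measured and on what is new or still open speak of the compounds shown alone.

Compound 2 `Cc1cnc(C(=O)Nc2cccc3ccc(C)nc23)cn1` reaches only the assay limit in a functional assay on BXPC-3 cells (Homo sapiens) for inhibition, read by MTT assay, with a stated time of 72 h (a lower number here means a stronger inhibitor, a higher number a weaker inhibitor), giving > 10000 nM. Compound 1 `Cc1ccc(C(=O)Nc2cccc3cccnc23)cn1` likewise gives > 10000 nM in this assay, again a limit rather than a number. Going by the values given here, both values sit at the limit of > 10000 nM in this assay, at which 2 of the 2 values shown sit, so no measured step exists. Compound 3 `Cc1ccc2cccc(NC(=O)c3cnccn3)c2n1` differs from compound 2 by hydrogen in place of methyl on an aromatic carbon. No step beyond the scatter is expected, in either direction, from compound 2 to compound 3 in this assay: the expected step is a step that the limit leaves unreadable from compound 2 to compound 3. Compound 3 is therefore estimated at 15000 nM, in the range 5000 nM to 50000 nM, most likely reported again as a limit.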

Compound 3, half-maximal inhibitory concentration: > 10000 nM
Compound 3 was reported as a limit; the forecaster's own chance of this, stated with the estimate: 80%; the middle value lies beyond the limit too.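

No step can be read from compound 2 to compound 3 in this assay, because both values are limits: the limit of > 10000 nM in this assay, at which 3 of the 3 values shown sit.

The compounds shown leave open whether going from 5-methylpyrazin-2-yl to pyrazin-2-yl changes inhibition, and how strongly any of them inhibits.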